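This account rests on a few compounds, and the source may have more. Where it says the series, first, only, none or still open, it means among the compounds named here.

Compound 1 `Cc1c(OCCCCOc2ccc(-n3cncn3)cc2)ccc(C(=O)CC(C)C)c1O` gives 4240 nM in a functional assay for binding affinity to metabotropic glutamate receptor 2 (Homo sapiens), read by GTPgammaS binding; on this read-out higher numbers stand for an effect only at larger amounts of compound and lower numbers for an effect already at smaller amounts.
Compound 2 `Cc1c(OCCCCOc2ccccc2)ccc(C(=O)CC(C)C)c1O` gives 4550 nM in this assay.
Compound 3 `CC(C)CC(=O)c1ccc(OCCCCOc2ccccc2)c(Br)c1O` gives 1500 nM in this assay.

Among these three, compound 3 shows the lowest number, and its gaps to compound 1 and to compound 2 both lie beyond the usual scatter, so compound 3 is the one that acts at the smallest amount. Compound 4 `CC(C)CC(=O)c1ccc(OCCCCSc2ccncc2)c(Br)c1O` has not yet been measured. It differs from compound 3 in one place: (pyridin-4-yl)sulfanyl in place of phenoxy on a saturated chain carbon, four bonds along the chain from an oxygen on an aromatic ring. Among the measured compounds shown here, no measured step makes this same exchange. The nearest comparison is the step from compound 1 to compound 2, where the 1H-1,2,4-triazol-1-yl group was removed and the result was a 1.1-fold higher number from compound 1 to compound 2 (0.03 log units; within the scatter). The step of a 3.0-fold lower number from compound 2 to compound 3 (0.48 log units; beyond the scatter) concerns a different part of the molecule and gives no guidance here. On this thin basis, a change in this part of the molecule is expected to matter little, and the step from compound 3 to compound 4 is estimated to be no change at the digits printed from compound 3 to compound 4 (within the scatter). Compound 4 is therefore expected to give about 1500 nM in this assay, within a range from 500 nM to 4500 nM.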

Compound 4, half-maximal effective concentration: 676 nM
For compound 4 the middle estimate is 2.2-fold (0.35 log units) above the measured one; measured number inside the range.
By their numbers in this assay, from the lowest: compound 4; then compound 3; then compounds 1 and 2 (each within the scatter of the next).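

Changes at the far end of the chain can move the number: in this assay, (pyridin-4-yl)sulfanyl in place of phenoxy gives a 2.2-fold lower number from compound 3 to compound 4 (0.35 log units; beyond the scatter). Among the compounds shown here, the earlier change to the phenoxy group, removing 1H-1,2,4-triazol-1-yl, gave only a 1.1-fold higher number from compound 1 to compound 2 (0.03 log units; within the scatter), so this is the first change in this part of the molecule to lie beyond the scatter. No measurement shown here explains the shift.

This exchange brings in both a sulfur and a ring nitrogen, so the compounds shown cannot tell which of the two goes with the lower number; phenylsulfanyl and pyridin-4-yloxy would separate them. Also open, going by these compounds, is how the number would respond to a longer chain, or to an amine at the end of the chain.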